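This account rests on a few compounds, and the source may have more. Where it says the series, first, only, none or still open, it means among the compounds named here.

Among the compounds with values here, compound 1, with the structure `CCC[C@@H](OC(C)=O)C1=C(Br)/C(=C/Br)OC1=O`, is the only compound in this set for which a plain number was obtained. In a functional assay on Lu1 cells (Homo sapiens) for cytotoxicity (a higher number here means that more compound is needed for the effect, a lower number that less compound is needed), compound 1 gives 1.7 ug/mL, and this stands as the sole measured figure against which anything else here can be judged. Compound 2, with the structure `CCC[C@@H](OC(C)=O)C1=C(Br)[C@@](C)(OC)OC1=O`, differs from compound 1 in more than one place, so the two cannot be compared as a single step. In this assay compound 2 reached only a limit, > 20 ug/mL, which means the assay reported no number for it; this is the limit of > 20 ug/mL in this assay, at which 1 of the 2 values shown sits.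

Compound 3, with the structure `CCCCC1=C(Br)/C(=C/Br)OC1=O`, has not yet been tested. It arises from compound 1 through one change: hydrogen in place of acetoxy on a saturated chain carbon bound to a double-bonded ring carbon and a saturated chain carbon. The shared core, with its two bromine atoms and the double bond outside the ring, stays unchanged.

Within the data shown here, no measured step bears on this change, so the expectation rests on compound 1 alone. The estimated step from compound 1 to compound 3, a 1.8-fold higher number from compound 1 to compound 3 (0.25 log units; within the scatter), is expected to stay close to the usual scatter, perhaps a modest weakening. Compound 3 is therefore estimated at 3 ug/mL, within a range of 1 ug/mL to 10 ug/mL.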

Compound 3, concentration for half-maximal effect: > 20 ug/mL
Compound 3 gave a limit, no number (the forecaster's own chance of this, stated with the estimate: 15%); at least 6.6-fold (0.82 log units) between middle value and limit.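

Within the data shown here, this is the only comparison in the set that changes a single place, so it gives the first direct reading of what the group on this saturated chain carbon contributes. In this assay, replacing acetoxy with hydrogen gives an at least 11-fold higher number from compound 1 to compound 3 (1.07 log units; beyond the scatter), so the shared core, with its two bromine atoms and its double bond outside the ring, does not give a plain number here without the acetoxy group. The reading for compound 3 is a limit and not a number, so the step shows a large loss but not its full size: the limit of > 20 ug/mL in this assay, at which 2 of the 3 values shown sit.

The compounds shown cannot tell whether the acetoxy group itself is required or whether almost any group other than hydrogen on this carbon would serve, and a hydroxyl group, a methoxy group or a longer ester at the same place would help to separate these possibilities. They also leave open whether the same change would have so large an effect on other cell types, or on a core carrying something other than bromine, such as chlorine.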